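The source may hold more compounds than are shown below. What is called first, only, known or untested is meant among the compounds shown, and "the series" means these compounds.

Measured in a functional assay on the whole organism for inhibition, with Rattus norvegicus as the target, read by cytopathic effect and paw edema, at a dose of 100 mg/kg by the oral route; a lower number here means less inhibition, a higher number more inhibition at the dose given (going by the name of the read-out):

compound 1 `CNC(=O)c1c(O)c2cccnc2n(-c2ccccc2)c1=O`, giving 21%
compound 2 `Nc1ccc(NC(=O)c2c(O)c3cccnc3n(-c3ccccc3)c2=O)cc1`, giving 0%
compound 3 `Cc1ccccc1NC(=O)c1c(O)c2cccnc2n(-c2ccccc2)c1=O`, giving 9.8%

Compound 3 sits second of the three. Its nearest neighbour is compound 2 with a number 9.8 percentage points higher from compound 2 to compound 3 (within the scatter), a gap within the scatter, so the two cannot be told apart. Compound 1 stands above it with a number 11.2 percentage points lower from compound 1 to compound 3 (beyond the scatter), which is beyond the scatter, and above compound 2 with a number 21 percentage points lower from compound 1 to compound 2 (beyond the scatter). Both aryl groups on the amide-type nitrogen therefore sit below the methyl of compound 1.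

Compound 4 `O=C(Nc1ccncc1)c1c(O)c2cccnc2n(-c2ccccc2)c1=O` follows from compound 3 by the change (pyridin-4-yl in place of 2-methylphenyl on an amide-type nitrogen). The bearing steps are the two that exchange one group on the same amide-type nitrogen: the move to 2-methylphenyl, a number 11.2 percentage points lower from compound 1 to compound 3 (beyond the scatter), and the move from 4-aminophenyl to 2-methylphenyl, a number 9.8 percentage points higher from compound 2 to compound 3 (within the scatter). Within the aryl pair the exchange of one six-membered aromatic ring for another was within the scatter; only the methyl-to-aryl step was beyond it. For the measured compounds named here, no measured step shows a ring with a hetero atom in this place, so nothing indicates a rise.

For compound 4 a value near that of compound 3 is expected, the step of a number 1.8 percentage points lower from compound 3 to compound 4 (within the scatter) staying within the scatter. Compound 4 is estimated at 8%, within 0% to 20%.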

Compound 4, a percentage reported as inhibition, in the whole organism at one dose (the size of the read-out at that dose, not a potency): 24.3%
Estimate against measurement, compound 4: 16.3 percentage points below; the whole stated range lies below it.
By their numbers in this assay, from the lowest: compounds 2 and 3 (each within the scatter of the next); then compounds 1 and 4 (each within the scatter of the next).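

In this assay, pyridin-4-yl on the amide-type nitrogen gives a number 14.5 percentage points higher from compound 3 to compound 4 (beyond the scatter) and a number 24.3 percentage points higher from compound 2 to compound 4 (beyond the scatter), so exchanging one six-membered aromatic ring for another at this position can move the number beyond the scatter, which the 4-aminophenyl and 2-methylphenyl pair had not shown. With a number 3.3 percentage points higher from compound 1 to compound 4 (within the scatter), pyridin-4-yl cannot be told apart from methyl, so a ring on this nitrogen does not in itself go with a lower number: the pattern of ring below methyl holds for 2-methylphenyl and 4-aminophenyl only, and compound 4 goes against it. Nothing measured on these compounds accounts for the separation between pyridin-4-yl and the two rings of carbon only.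

The compounds shown leave open whether the ring nitrogen or the substituents on the two carbon-only rings decide the difference, a question that unsubstituted phenyl, pyridin-3-yl and pyridin-2-yl on the same nitrogen would address. They also leave open how a longer alkyl chain, or a chain ending in an amine or a carboxylic acid, would compare with methyl and pyridin-4-yl at this nitrogen.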